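A few compounds are considered here, and "the series" means these few. Any claim that something is new, unique, unknown or untested is made for them only; others in the source may bear on it.

Among the compounds with values here, in a functional assay on A549 cells (Homo sapiens) for antiproliferative activity (a higher number here means a weaker inhibitor of growth, a lower number a stronger inhibitor of growth), compound 1 (`CC/C=C\[C@H](C)[C@H](OC(N)=O)[C@@H](C)[C@H](O)[C@@H](C)C/C(C)=C\[C@H](C)[C@@H](O)[C@@H](C)/C=C\[C@@H](O)C[C@H]1CCC(=O)O1`) gives 63 nM and compound 2 (`CC/C=C\[C@H](C)[C@H](OC(N)=O)[C@@H](C)[C@H](O)[C@@H](C)C/C(C)=C\[C@H](C)[C@@H](O)[C@@H](C)/C=C\[C@@H](O)C[C@@H]1OC(=O)NC[C@H]1C`) gives 1000 nM as the higher of the two numbers so far, making compound 2 the weaker growth inhibitor of the pair. Compound 3 (`CC/C=C\[C@H](C)[C@H](OC(N)=O)[C@@H](C)[C@H](O)[C@@H](C)C/C(C)=C\[C@H](C)[C@@H](O)[C@@H](C)/C=C\[C@@H](O)C[C@@H]1OC(=O)[C@H](C)[C@@H](OC)[C@H]1C`) is not yet measured and departs from compound 2 at one place (a group of 11 heavy atoms (8 carbon, 3 oxygen; one six-membered non-aromatic ring with 1 hetero atom) in place of a group of 8 heavy atoms (5 carbon, 1 nitrogen, 2 oxygen; one six-membered non-aromatic ring with 2 hetero atoms), on a saturated chain carbon, two bonds along the chain from a double-bonded chain carbon and an oxygen on a saturated carbon) where a six-membered non-aromatic ring with 1 hetero atom replaces one with 2 hetero atoms. Within the data shown here, the only measured step at that place is large (a 16-fold higher number from compound 1 to compound 2 (1.20 log units; beyond the scatter)) and shows that the number in this assay moves strongly with the group there. Among the measured compounds shown here, no measured compound carries the entering group, so the direction remains uncertain. A sizeable move toward a lower number is expected, with compound 1 at 63 nM as the nearest guide. The expected change is a 10-fold lower number from compound 2 to compound 3 (1.00 log units; beyond the scatter) as estimated here. For compound 3 the estimated value is 100 nM with an expected range from 20 nM to 500 nM in this series.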

Compound 3, concentration for 50% growth inhibition: 12 nM
Estimate against measurement, compound 3: 8.3-fold (0.92 log units) above; the measured number lies below the stated range.
By their numbers in this assay, from the lowest: compound 3; then compound 1; then compound 2.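

In this assay, the position proves able to carry a larger group without loss: the group of 11 heavy atoms gives an 83-fold lower number from compound 2 to compound 3 (1.92 log units; beyond the scatter), and it also gives a 5.3-fold lower number from compound 1 to compound 3 (0.72 log units; beyond the scatter), so the five-membered ring of compound 1 does not mark the low end of the range at this place. The ring size alone does not set the number, as compound 2 and compound 3 both carry a six-membered non-aromatic ring yet lie far apart. No measurement here bears on why the number moves with this change.

The entering group differs from the one in compound 2 in hetero atoms, hydrogen-bond donors and defined stereocentres all at once, and these shown steps cannot separate them. From the compounds shown here alone, how a six-membered ring carrying an amine or a carboxylic acid at this place would read remains open.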